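A few compounds are considered here, and "the series" means these few. Any claim that something is new, unique, unknown or untested is made for them only; others in the source may bear on it.

Compound 1 `CCNC(=O)c1noc(-c2cc(C(C)C)c(O)cc2O)c1-c1cc(CNC)no1`: "not determined" (no result reported)
Compound 2 `CCNC(=O)c1noc(-c2cc(C(C)C)c(O)cc2O)c1-c1cc(CNCCO)no1`: "not determined" (no result reported)
Compound 3 `CCNC(=O)c1cc(-c2c(C(=O)NCC)noc2-c2cc(C(C)C)c(O)cc2O)on1`: 43 nM

These entries come from a functional assay on A2780 cells (Homo sapiens) for inhibition; on this read-out higher numbers stand for weaker inhibition and lower numbers for stronger inhibition. Only compound 3 has a number, at 43 nM, so it cannot yet be ranked against anything. Among the compounds with values here, no measured pair shows how much a change at this part of the molecule matters.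

Compound 4 `CCCn1ccc(-c2c(C(=O)NCC)noc2-c2cc(C(C)C)c(O)cc2O)n1` has not yet been measured. It carries 1-propyl-1H-pyrazol-3-yl in place of 3-(ethylcarbamoyl)-1,2-oxazol-5-yl on an aromatic carbon. The rest of the molecule stays the same. Both groups hold one five-membered aromatic ring with 2 hetero atoms, but the ethylcarbamoyl group on the departing ring is lost and a propyl group arrives.

Within the data shown here, with no measured step to lean on, the expectation starts from compound 3 at 43 nM and stays cautious. No shift beyond the usual scatter is expected in this assay, with slightly weaker inhibition the more likely direction, though a real move either way is possible. The estimated change is a 1.3-fold higher number from compound 3 to compound 4 (0.11 log units; within the scatter). For compound 4 the expected value is 55 nM, with an estimated range from 15 nM to 200 nM.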

Compound 4, half-maximal inhibitory concentration: 27 nM
Beside the measured number, compound 4's estimate is 2.0-fold (0.31 log units) above it; the measured number falls inside the stated range.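

In this assay, this first readable step at the position, a 1.6-fold lower number from compound 3 to compound 4 (0.20 log units; within the scatter), does not separate the two groups. On this read-out, the 3-(ethylcarbamoyl)-1,2-oxazol-5-yl group can therefore give way to 1-propyl-1H-pyrazol-3-yl without a change beyond the usual scatter, even though the ethylcarbamoyl group and its amide hydrogen leave and a propyl group arrives, so the ethylcarbamoyl group is not required for a number in this range in this one pair. No measured evidence here explains this result.

From the compounds shown here alone, compound 1 and compound 2 have no numbers, so the steps that would link them to the other compounds cannot be read, and the effect of their amine side chains on this read-out stays unknown. Going by these compounds, it also remains open whether a longer chain such as butyl or hexyl on the pyrazole nitrogen, or a carboxylic acid on the ring at this position, would leave the number within the scatter or move it clearly in either direction.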